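From 3-methoxyphenyl to 2-methoxyphenyl in compound 1

The source may report more compounds than this note shows. Statements on the series, on what has been measured and on what is new or still open speak of the compounds shown alone.

- compound 1 `COc1cccc(/C=C/C(=O)/C=C/c2ccc(OCc3cn(CCOc4cc(=O)oc5ccccc45)nn3)c(OC)c2)c1` gives 11900 nM
- compound 2 `COc1cc(/C=C/C(=O)/C=C/c2cc(OC)c(OC)c(OC)c2)ccc1OCc1cn(CCCOc2cc(=O)oc3ccccc23)nn1` gives 10600 nM

In a functional assay on COLO 205 cells (Homo sapiens) for cytotoxicity, read by sulforhodamine B assay, with a stated time of 48 h (a higher number here means a weaker inhibitor, a lower number a stronger inhibitor), compound 1 and compound 2 lie within the usual scatter of each other, so the two cannot be ranked. Compound 3 `COc1ccccc1/C=C/C(=O)/C=C/c1ccc(OCc2cn(CCOc3cc(=O)oc4ccccc34)nn2)c(OC)c1` has 2-methoxyphenyl in place of 3-methoxyphenyl on a double-bonded chain carbon bound to a double-bonded chain carbon. Among the compounds with values here, no measured pair shows this swap, so the estimated step of a 1.2-fold lower number from compound 1 to compound 3 (0.08 log units; within the scatter) in this assay is expected to stay within the usual scatter, with no firm direction. The estimate for compound 3 is 10000 nM (expected range 5000 nM to 20000 nM).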

Compound 3, half-maximal inhibitory concentration: 11500 nM
The estimate for compound 3 lay 1.2-fold (0.06 log units) below the measured number; the measured number falls inside the stated range.
By their numbers in this assay, from the lowest: compounds 2, 3 and 1 (each within the scatter of the next).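

Moving the methoxy group, from 3-methoxyphenyl to 2-methoxyphenyl, gives the first direct reading at this position: in this assay the step is a 1.0-fold lower number from compound 1 to compound 3 (0.01 log units; within the scatter). On a double-bonded chain carbon bound to a double-bonded chain carbon, the two groups therefore cannot be told apart. Nothing available bears on this result.

Still open, from the compounds shown here alone, is whether a different group at this place, such as an amine or a carboxylic acid on the ring in place of methoxy, would shift the number beyond the scatter.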